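The source may hold more compounds than are shown below. What is called first, only, known or untested is meant among the compounds shown, and "the series" means these compounds.

Working notes on the series. The shared core is that of compound 1 `OC(c1ccc(Cl)cc1)(c1cccnc1)c1ccccc1F`; compound 2 `OC(c1ccc(Cl)cc1)(c1cccnc1)c1ccccc1C(F)(F)F` and compound 3 `OC(c1ccc(Cl)cc1)(c1cccnc1)c1ccc(F)cc1F` are measured, while compound 4 `OC(c1ccc(Cl)cc1)(c1cccnc1)c1ccc(C(F)(F)F)cc1F` is not yet.

In an ADME assay on L6 cells (Rattus norvegicus) for cytotoxicity, read by resazurin assay, with a stated time of 72 h (a lower number here means a stronger inhibitor, a higher number a weaker inhibitor), compound 1 gives only a limit, > 100000 nM. In this assay compound 2 gives 59300 nM, and compound 3 gives 70200 nM. The step of an at least 1.6-fold lower number from compound 1 to compound 2 (0.22 log units; that floor lies within the scatter) is a floor because the limit of > 100000 nM in this assay, at which 1 of the 3 values shown sits, caps its starting value, and the same holds for an at least 1.4-fold lower number from compound 1 to compound 3 (0.15 log units; that floor lies within the scatter). Compound 2 and compound 3 sit within the scatter of each other.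

The change from compound 1 to compound 2 is trifluoromethyl in place of fluoro on an aromatic carbon, and the change from compound 3 to compound 4 is trifluoromethyl in place of fluoro on an aromatic carbon. The two cores differ by fluoro in place of hydrogen on an aromatic carbon. The surroundings are not identical: in the first case the entering group sits ortho to a large group, in the second meta to a fluoro group and para to a large group, so the change is of the same kind rather than the same.

Resting on the floor an at least 1.6-fold lower number from compound 1 to compound 2 (0.22 log units; that floor lies within the scatter), compound 4 is expected to move by a 1.6-fold lower number from compound 3 to compound 4 (0.19 log units; within the scatter) in this assay. Compound 4 is estimated at 45000 nM in this assay.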

Compound 4, half-maximal inhibitory concentration: 57400 nM
Compound 4: the middle estimate sits 1.3-fold (0.11 log units) below what was measured; measured number inside the range.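

In this assay, trifluoromethyl in place of fluoro on the core of compound 3 gives a 1.2-fold lower number from compound 3 to compound 4 (0.09 log units; within the scatter), and the other new step is an at least 1.7-fold lower number from compound 1 to compound 4 (0.24 log units; that floor lies within the scatter). Set beside the earlier step, the new one shows that the change gives a small step on the core of compound 3, but the step on the core of compound 1 is known only as a floor, so the comparison supports neither a shared size nor a different one: the same change on two cores in this assay, an at least 1.6-fold lower number (0.22 log units; that floor lies within the scatter) from compound 1 to compound 2 and a 1.2-fold lower number (0.09 log units; within the scatter) from compound 3 to compound 4; the limit leaves it open whether they differ. Compound 1 gives > 100000 nM, which is a limit and not a number, so these compounds do not show whether the size of this change carries from one core to the other.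

On these data alone, the substituents varied here are only fluoro and trifluoromethyl, so the effect of an amine, a carboxylic acid or a longer chain in their place remains open. Also open, as far as these compounds go, is whether any change on the shared core gives a step in this assay that is clearly beyond the scatter.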